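Carboxy in Place of Hydroxy: an Expected Antiproliferative Read-out

A few compounds are considered here, and "the series" means these few. Any claim that something is new, unique, unknown or untested is made for them only; others in the source may bear on it.

Of the compounds shown here, two have so far been measured in a functional assay on Hep 3B2 cells (Homo sapiens) for antiproliferative activity, read by MTT assay, with a stated time of 24 h, tested at 0.02 ug/mL; on this read-out higher numbers stand for a stronger effect at the one concentration tested and lower numbers for a weaker effect. Compound 1 `Cc1c(C(=O)Nc2ccc(-c3ccccc3)cc2)nc2ccccc2c1O` gives 1.05% in this assay. Compound 2 `CCc1ccc2nc(C(=O)Nc3c(F)cc(-c4cccc(F)c4)cc3F)c(C)c(C(=O)O)c2c1` gives -0.05% in this assay. The two numbers lie within the scatter of each other, so compound 1 stands level with compound 2 on what is known, and neither can be called the stronger. Going by the values given here, both numbers sit close to zero, which means that at the one concentration tested neither compound produced a measurable effect.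

Compound 3 `Cc1c(C(=O)Nc2ccc(-c3ccccc3)cc2)nc2ccccc2c1C(=O)O` has not yet been measured in this assay. It differs from compound 1 in one place: carboxy in place of hydroxy on an aromatic carbon. Among the compounds with values here, no step between two measured compounds shows what such a change does in this assay, so the expectation for compound 3 rests only on the numbers of compound 1 and compound 2, both of which are essentially null. The expected step of a number 1 percentage points higher from compound 1 to compound 3 (within the scatter) is accordingly none beyond the scatter. Compound 3 is therefore estimated at 2% in this assay, within a range from -8% to 12%.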

Compound 3, a percentage reported as inhibition, at one concentration (the size of the read-out at that concentration, not a potency): -0.35%
For compound 3 the middle estimate is 2.4 percentage points above the measured one; low and high end bracket the measured number.
By their numbers in this assay, from the lowest: compounds 3, 2 and 1 (each within the scatter of the next).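

In this assay, carboxy in place of hydroxy on an aromatic carbon, opposite the ring nitrogen and ortho to a methyl group, gives a number 1.4 percentage points lower from compound 1 to compound 3 (within the scatter). Going by these compounds alone, this is the first step between two measured compounds that differ in one place, and it shows that on the core of compound 1 this exchange does not lift the read-out away from zero at the one concentration tested, so hydroxy and carboxy cannot be told apart at this position by this read-out. Nothing measured here speaks to the reason for this outcome.

As far as these compounds go, whether another group on this same aromatic carbon, such as an amine or a methoxy group, or a longer chain in place of the neighbouring methyl group, would bring the read-out clear of the scatter remains open. From the compounds shown here alone, it is also open whether compound 1 and compound 3 would separate at a concentration other than the one tested, since a read-out this close to zero says little about any difference that might appear where the effect is larger.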